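The source may report more compounds than this note shows. Statements on the series, on what has been measured and on what is new or still open speak of the compounds shown alone.

Within the data shown here, in a functional assay on A-431 cells (Homo sapiens) for cytotoxicity, read by MTT assay, with a stated time of 48 h (on this read-out higher numbers stand for weaker inhibition and lower numbers for stronger inhibition), compound 3 `CCCCCCCCCCCCCCNC(=O)[C@@H](NC(=O)c1cc2ccccc2o1)[C@@H](C)O` gives 20100 nM, the second highest of the three numbers known; compound 2 `CCCCCCCCCCCCNC(=O)[C@@H](NS(=O)(=O)c1cccs1)[C@@H](C)O` gives 22000 nM and compound 1 `CCCCCCCCCCCCCCNC(=O)[C@@H](N)[C@@H](C)O` gives 14600 nM, both within the scatter of it. Compound 4 `CCCCCCCCCCCCCCNC(=O)[C@@H](NS(=O)(=O)c1cccs1)[C@@H](C)O` differs from compound 3 in one place: (thiophen-2-yl)sulfonyl in place of (1-benzofuran-2-yl)carbonyl on an amine nitrogen. Among the measured compounds shown here, the one measured step that touches this nitrogen, a 1.4-fold higher number from compound 1 to compound 3 (0.14 log units; within the scatter), changed nothing beyond the scatter. Compound 2 carries the same (thiophen-2-yl)sulfonyl group, and its number sits close to that of compound 3. A step of no size beyond the scatter is therefore expected, a 1.0-fold lower number from compound 3 to compound 4 (0.00 log units; within the scatter). Compound 4 is estimated at 20000 nM, with a range from 10000 nM to 40000 nM.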

Compound 4, half-maximal inhibitory concentration: 22000 nM
Beside the measured number, compound 4's estimate is 1.1-fold (0.04 log units) below it; low and high end bracket the measured number.
By their numbers in this assay, from the lowest: compounds 1, 3, 2 and 4 (each within the scatter of the next).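

In this assay the read-out stays within the scatter when (thiophen-2-yl)sulfonyl replaces (1-benzofuran-2-yl)carbonyl on the amine nitrogen (a 1.1-fold higher number from compound 3 to compound 4 (0.04 log units; within the scatter)) and when it replaces hydrogen there (a 1.5-fold higher number from compound 1 to compound 4 (0.18 log units; within the scatter)). Ethyl in place of hydrogen on a saturated chain carbon also stays within the scatter (no change at the digits printed from compound 2 to compound 4 (within the scatter)). No measurement bears on why these changes leave the number within the scatter. Still open, going by these compounds, is whether an acetyl group or a carboxylic acid on this nitrogen would move the number beyond the scatter. A much shorter chain also remains untested among these compounds.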